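The compounds below may be only part of what the source reports. "The series", "measured", "known", "first", "only" and "open" are said of these compounds alone.

Working notes on the series. In an ADME assay on a cell-free system (plasma, Mus musculus) for metabolic stability, read by HPLC, with a stated time of 120 min, tested at 2 uM (a higher number here means that the compound lasts longer, a lower number that the compound disappears faster), compound 1 `COc1nc2ccccc2n1C(=O)NCCCCc1ccccc1` gives > 2 h, which is a limit of the assay and not a number. Among the compounds with values here, only this one compound sits there: the limit of > 2 h in this assay, at which 1 of the 3 values shown sits. Compound 2 `CCCCCCNC(=O)n1nnc2ccccc21` gives 0.217 h, and compound 3 `CCCCCCNC(=O)N1C(=O)c2ccccc2C1=O` gives 0.483 h. Compound 4 `Nc1nc2ccccc2n1C(=O)NCCCCc1ccccc1` keeps the core of compound 1 and carries amino in place of methoxy on an aromatic carbon. Within the data shown here, no measured pair shows this change, so the expectation in this assay is tentative: a moderate fall, with an at least 1.3-fold lower number from compound 1 to compound 4 (0.12 log units; that floor lies within the scatter) as the expected step. For compound 4 the estimated half-life is 1.5 h, with an expected range of 0.4 h to 5 h.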

Compound 4, half-life: 0.15 h
The estimate for compound 4 lay 10-fold (1.00 log units) above the measured number; measured number outside the range, below it.
By their numbers in this assay, from the lowest: compounds 4 and 2 (each within the scatter of the next); then compound 3. At a limit, above all of these: compound 1.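

With the rest of the structure unchanged, amino in place of methoxy on an aromatic carbon, between two ring nitrogen atoms, gives in this assay an at least 13-fold lower number from compound 1 to compound 4 (1.12 log units; beyond the scatter). This is the only step shown in the series, and it places strong weight on this one position. Its full size cannot be read, as compound 1 stands at a limit of the assay and not at a number: the limit of > 2 h in this assay, at which 1 of the 4 values shown sits.

The compounds shown leave open how methyl, ethoxy or dimethylamino would behave at this position. They also leave open whether the effect of amino carries over to a shorter chain on the urea.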